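The source may report more compounds than this note shows. Statements on the series, on what has been measured and on what is new or still open speak of the compounds shown alone.

Measured in a functional assay on HeLa cells (Homo sapiens) for antiproliferative activity, read by CCK-8 assay, with a stated time of 72 h; a higher number here means a weaker inhibitor, a lower number a stronger inhibitor:
compound 1 `CCc1ccc(SCc2ccc(C(=O)Nc3ccccc3N)cc2)cc1`: 3800 nM
compound 2 `Nc1ccccc1NC(=O)/C=C/c1ccc(CSc2cccc3ccccc23)cc1`: "not determined" (no result reported)

For the measured compounds named here, compound 1 holds the only number so far, and compound 2 has no reported result, so compound 1 cannot yet be ranked against anything. Compound 3 `Nc1ccccc1NC(=O)c1ccc(CSc2ccc(F)cc2)cc1` keeps the core of compound 1 and changes in one place: fluoro in place of ethyl on an aromatic carbon. Going by the values given here, no measured pair shows what this swap does, so in this assay no step beyond the scatter is expected, in either direction, with compound 1 at 3800 nM as the only anchor. The expected change is a 1.1-fold lower number from compound 1 to compound 3 (0.04 log units; within the scatter). For compound 3 the estimate is 3500 nM, expected between 1200 nM and 10000 nM.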

Compound 3, half-maximal inhibitory concentration: 5010 nM
Compound 3: middle estimate off by 1.4-fold (0.16 log units), on the low side; low and high end bracket the measured number.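

Swapping ethyl for fluoro on this aromatic carbon in this assay gives a step that stays within the scatter (a 1.3-fold higher number from compound 1 to compound 3 (0.12 log units; within the scatter)). This first measured pair therefore does not separate the 4-ethylphenyl and 4-fluorophenyl forms, even though the entering group has fewer heavy atoms than the one leaving. No available evidence bears on this result.

Going by these compounds, whether other groups at this position would also leave the number within the scatter stays open. An amine, a carboxylic acid or a longer carbon chain here could behave differently.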